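A methoxy group added to compound 1

The source may hold more compounds than are shown below. What is called first, only, known or untested is meant among the compounds shown, and "the series" means these compounds.

Compound 1 (`COc1ccc(Cl)cc1NC(=O)Cc1nn(CC(=O)O)c(=O)c2ccccc12`) gives (1.9)
Compound 2 (`O=C(O)Cn1nc(Cc2nc3cc(Cl)c(OC(F)(F)F)cc3[nH]2)c2ccccc2c1=O`) gives (2.54)

In a physicochemical assay for lipophilicity, at pH 7.4 (on this read-out lower numbers stand for lower lipophilicity and higher numbers for higher lipophilicity), compound 1 stands lowest of the two, and compound 2 lies higher by more than the usual scatter. Compound 3 (`COc1cc(OC)c(NC(=O)Cc2nn(CC(=O)O)c(=O)c3ccccc23)cc1Cl`) has not yet been measured. It keeps the core of compound 1 and carries methoxy in place of hydrogen on an aromatic carbon, ortho to a chloro group, meta to a methoxy group and para to a large group (methoxy in place of hydrogen on an aromatic carbon). Going by the values given here, no pair of measured compounds shows this change. The expectation therefore rests only on compound 1 (1.9) and the change itself. In this assay a slight upward shift is expected, but none beyond the scatter, and the estimated move is a number 0.10 log units higher from compound 1 to compound 3 (within the scatter) in size. For compound 3 the estimate is 2 with an expected range (1.6 to 2.4).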

Compound 3, distribution coefficient: 1.64
For compound 3 the middle estimate is 0.36 log units above the measured one; the range from low to high includes it.
By their numbers in this assay, from the lowest: compounds 3 and 1 (each within the scatter of the next); then compound 2.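

In this assay, going by these compounds alone, methoxy in place of hydrogen on an aromatic carbon, ortho to a chloro group, meta to a methoxy group and para to a large group, gives a number 0.26 log units lower from compound 1 to compound 3 (within the scatter), the only step here between compounds that differ in one place. It shows that this position on the core of compound 1 can take a methoxy group with the read-out staying within the scatter, something the two earlier compounds, which differ in more than one place, could not show. The data shown offer no measured reason for this outcome.

Still open, going by these compounds, is whether an amine, a carboxylic acid or a longer alkoxy chain on this same aromatic carbon would also stay within the scatter of compound 1. Also open, on these data alone, is whether methoxy would behave the same way at another carbon of this ring.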